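The compounds below may be only part of what the source reports. "The series", "measured", "known", "first", "only" and "open" are said of these compounds alone.

Within the data shown here, in a functional assay on HL-60 cells (Homo sapiens) for cytotoxicity, read by CCK-8 assay, with a stated time of 24 h (a higher number here means a weaker inhibitor, a lower number a stronger inhibitor), compound 1 (`C=CC(=O)N1C(=O)CC(c2ccc(C)cc2)Sc2ccccc21`) gives 94400 nM and compound 2 (`C=CC(=O)N1C(=O)CC(c2cccc(Cl)c2)Sc2ccccc21`) gives 93100 nM on the same core, so compound 1 stands level with the only other measured compound. Compound 3 (`C=CC(=O)N1C(=O)CC(c2ccc(-c3ccccc3)cc2)Sc2ccccc21`) departs from compound 1 by a single change (phenyl in place of methyl on an aromatic carbon) with phenyl in place of methyl on an aromatic carbon, para to a large group. Among the measured compounds shown here, one measured step bears on this, and only loosely. It is a 1.0-fold lower number from compound 1 to compound 2 (0.01 log units; within the scatter) for 3-chlorophenyl in place of 4-methylphenyl on a saturated ring carbon. For the measured compounds named here, that step alters the substituent on the same aromatic ring but adds no second ring, and the data hold no example of such an addition. With that single flat step as the guide, no change beyond the scatter is expected in this assay for compound 3, though a modest shift in either direction cannot be excluded. The expected step is a 1.3-fold lower number from compound 1 to compound 3 (0.10 log units; within the scatter) and remains a rough estimate. Compound 3 is expected at 75000 nM with an estimated range of 30000 nM to 180000 nM on this measure.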

Compound 3, half-maximal inhibitory concentration: 118000 nM
The estimate for compound 3 lay 1.6-fold (0.20 log units) below the measured number; measured number inside the range.
By their numbers in this assay, from the lowest: compounds 2, 1 and 3 (each within the scatter of the next).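

In this assay, replacing methyl with phenyl on an aromatic carbon, para to a large group, gives a 1.3-fold higher number from compound 1 to compound 3 (0.10 log units; within the scatter) and so leaves the number within the scatter. The earlier pair changed only the substituent on this aromatic ring, whereas this step adds a second one, a six-membered aromatic ring of carbon only, and shows that even this much larger group does not move the read-out beyond the scatter at this position. Nothing measured alongside these numbers gives a reason for this flat result.

The compounds shown leave open whether this position stays as flat with an amine, a carboxylic acid or a longer chain in place of methyl, since the groups seen here, methyl and phenyl, are made of carbon and hydrogen only. They also leave open whether any change elsewhere on the shared core would shift the number beyond the scatter, as the only other step shown, a 1.0-fold lower number from compound 1 to compound 2 (0.01 log units; within the scatter), also concerns the aromatic ring on the saturated ring carbon.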